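A few compounds are considered here, and "the series" means these few. Any claim that something is new, unique, unknown or untested is made for them only; others in the source may bear on it.

Of the compounds shown here, three from this series have been measured in an assay for inhibition of Indoleamine 2,3-dioxygenase 1 (Homo sapiens), with stated times of 10 min and 60 min, tested at 10 uM; on this read-out higher numbers stand for a stronger effect at the one concentration tested and lower numbers for a weaker effect. Compound 1, with the structure `O=[N+]([O-])c1cccc(CNc2cc(Br)cc3[nH]ncc23)c1`, gives 72% in this assay. Compound 2, with the structure `N#Cc1cc(NCc2ccccc2[N+](=O)[O-])c2cn[nH]c2c1`, gives 7%, and compound 3, with the structure `O=C(O)c1cccc(CNc2cc(C(F)(F)F)cc3[nH]ncc23)c1`, gives 11%. Compound 2 thus holds the lowest of the three numbers; its value sits within the usual scatter of that of compound 3, so the two cannot be told apart, while compound 1 lies well beyond the scatter above it.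

The next compound to consider is compound 4, with the structure `O=[N+]([O-])c1ccccc1CNc1cc(C(F)(F)F)cc2[nH]ncc12`. It differs from compound 2 in one place: trifluoromethyl in place of cyano on an aromatic carbon.

Going by the values given here, no measured pair shows this exchange directly, so its effect in this assay is unknown. Because compound 3, which carries a trifluoromethyl group, gives 11%, a number close to that of compound 2, only a small step is expected, if any, from compound 2 to compound 4, and a rise of a number 8 percentage points higher from compound 2 to compound 4 (within the scatter) is estimated. Compound 4 is therefore expected to give about 15%, with a likely range from 0% to 40%.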

Compound 4, a percentage reported as inhibition, at one concentration (the size of the read-out at that concentration, not a potency): 35%
Beside the measured number, compound 4's estimate is 20 percentage points below it; the range from low to high includes it.
By their numbers in this assay, from the lowest: compounds 2 and 3 (each within the scatter of the next); then compound 4; then compound 1.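

In this assay, trifluoromethyl in place of cyano on this aromatic carbon gives a number 28 percentage points higher from compound 2 to compound 4 (beyond the scatter), so with the rest of the molecule unchanged, the group at this place on the shared core clearly affects the read-out. The exchange replaces a cyano group, counted as a hydrogen-bond acceptor, with a trifluoromethyl group that has more heavy atoms and is not counted as one, and this single pair cannot show which of these differences matters. Nothing measured here explains the rise.

As far as these compounds go, it remains open how a methyl group, a methoxy group or an amine would compare on this same aromatic carbon. From the compounds shown here alone, it is also open whether this exchange would give a similar step if another part of the molecule were different.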